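Swapping the side ring on a resorcinol isoxazole amide series

The source may report more compounds than this note shows. Statements on the series, on what has been measured and on what is new or still open speak of the compounds shown alone.

Measured compounds:
- compound 1 `CCNC(=O)c1noc(-c2cc(C(C)C)c(O)cc2O)c1-c1cc(COCC(=O)OC)no1` — "not determined" (no result reported)
- compound 2 `CCCNCc1cc(-c2c(C(=O)NCC)noc2-c2cc(C(C)C)c(O)cc2O)on1` — "not determined" (no result reported)
- compound 3 `CCNC(=O)c1noc(-c2cc(C(C)C)c(O)cc2O)c1-c1cc(CN(CC)CC)no1` — 78 nM

Three compounds share one core and differ only in the group carried on the side ring. In a functional assay on A2780 cells (Homo sapiens) for inhibition (a higher number here means a weaker inhibitor, a lower number a stronger inhibitor), compound 3 gives 78 nM. For compound 1 the entry is "not determined" (no result reported), and for compound 2 the entry is "not determined" (no result reported), so compound 2 stands without a number of its own, and the only anchor in this assay is compound 3.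

The step to compound 4 `CCNC(=O)c1noc(-c2cc(C(C)C)c(O)cc2O)c1-c1ccn(C)n1` changes the side group: 1-methyl-1H-pyrazol-3-yl in place of 3-((propylamino)methyl)-1,2-oxazol-5-yl on an aromatic carbon. For the measured compounds named here, no measured pair shows this change directly, so the size of the step can only be judged from compound 3. Since compound 2 itself has no number, the direction of the step cannot be read from the data; a moderate shift, beyond the scatter but not large, is expected.

Compound 4 is expected to give 150 nM in this assay, with a range from 40 nM to 600 nM.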

Compound 4, half-maximal inhibitory concentration: 12 nM
Compound 4: the middle estimate sits 13-fold (1.10 log units) above what was measured; measured number outside the range, below it.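

For the compounds shown here, compound 2 has no single number in this assay, so no step from it to compound 4 can be read. The compounds shown leave open how much swapping the side group alters inhibition. Nothing available here bears on the result for compound 4.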